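Swapping the aryl group on a fused pyrazolo core

The source may report more compounds than this note shows. Statements on the series, on what has been measured and on what is new or still open speak of the compounds shown alone.

Measured so far in a functional assay on HCT-116 cells (Homo sapiens) for inhibition, read by CCK-8 assay, with a stated time of 48 h; a higher number here means a weaker inhibitor, a lower number a stronger inhibitor:
- compound 1, `COc1cc(-c2ccnc3cc(-c4ccc(C)cc4)nn23)cc(OC)c1OC`: 48 nM
- compound 2, `Cn1ccc2cc(-c3cc4nccc(-c5ccc(F)cc5)n4n3)ccc21`: 2160 nM
- compound 3, `COc1ccc(-c2cc3nccc(-c4cc(OC)c(OC)c(OC)c4)n3n2)cc1[N+](=O)[O-]`: a limit, > 10000 nM

Compound 1 gives the lowest of the two numbers in this assay, and compound 2 sits well beyond the usual scatter from it, so compound 1 is the stronger inhibitor of the pair. For compound 3 the assay reports only a limit and no number; that is the limit described by the limit of > 10000 nM in this assay, at which 1 of the 3 values shown sits. Compound 3 carries a 4-methoxy-3-nitrophenyl group where compound 1 carries a 4-methylphenyl group.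

Compound 4, `COc1ccc(-c2cc3nccc(-c4cc(OC)c(OC)c(OC)c4)n3n2)cc1F`, is not yet measured. It differs from compound 1 in one place: 3-fluoro-4-methoxyphenyl in place of 4-methylphenyl on an aromatic carbon

Going by the values given here, no measured pair differs in exactly this way, so the size of the step is uncertain. Compound 3, which also carries a methoxy group with a further substituent on that ring, sits at a limit. Compound 1 gives 48 nM, so a loss of potency beyond the scatter is expected for compound 4, though smaller than the gap to compound 3. The step of a 5.2-fold higher number from compound 1 to compound 4 (0.72 log units; beyond the scatter) is the expected size. Compound 4 is therefore estimated at 250 nM, with a range from 50 nM to 2500 nM.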

Compound 4, half-maximal inhibitory concentration: 2840 nM
Compound 4: the middle estimate sits 11-fold (1.06 log units) below what was measured, and the stated range ends below it.
By their numbers in this assay, from the lowest: compound 1; then compounds 2 and 4 (each within the scatter of the next). At a limit, above all of these: compound 3.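

Replacing 4-methylphenyl with 3-fluoro-4-methoxyphenyl on this aromatic carbon of the five-membered ring gives a 59-fold higher number from compound 1 to compound 4 (1.77 log units; beyond the scatter) in this assay, so potency here depends strongly on which aryl group is attached. Within the methoxy-bearing aryl group, a single substituent also matters: fluoro in place of nitro gives an at least 3.5-fold lower number from compound 3 to compound 4 (0.54 log units; beyond the scatter), which shows that this ring can still change the result even when the rest of the molecule stays the same. That step has a lower bound only, since compound 3 gives a limit and not a number: the limit of > 10000 nM in this assay, at which 1 of the 4 values shown sits.

The step from compound 1 to compound 4 adds the methoxy and fluoro groups and removes the methyl group in one move, so the compounds shown cannot tell whether the loss follows from one of these changes or from their combination, which a phenyl ring bearing only the methoxy group or only the fluoro group could separate. Going by these compounds, it also remains open how this position would respond to a quite different substituent on the aryl ring, such as an amine or a carboxylic acid.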